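Benzyl ring substitution: methoxycarbonyl added to compound 2

A few compounds are considered here, and "the series" means these few. Any claim that something is new, unique, unknown or untested is made for them only; others in the source may bear on it.

Compound 1 `Cn1c2ccccc2[n+]2nc3c(cc12)-c1cccc2cccc-3c12` gives 3700 nM in a functional assay on HT-29 cells (Homo sapiens) for inhibition, with a stated time of 72 h; on this read-out higher numbers stand for an effect only at larger amounts of compound and lower numbers for an effect already at smaller amounts. Among the compounds with values here, compound 2 `c1ccc(Cn2c3ccccc3[n+]3nc4c(cc23)-c2cccc3cccc-4c23)cc1` gives 1500 nM in this assay, the lower of the two numbers measured so far; the only measured step, a 2.5-fold lower number from compound 1 to compound 2 (0.39 log units; beyond the scatter), separates it from compound 1. Compound 3 `COC(=O)c1ccc(Cn2c3ccccc3[n+]3nc4c(cc23)-c2cccc3cccc-4c23)cc1` is not yet measured. Its change from compound 2 is methoxycarbonyl in place of hydrogen on an aromatic carbon. Within the data shown here, no measured step bears directly on this change: the one step known concerns phenyl in place of hydrogen on the saturated chain carbon bound to an aromatic nitrogen, not a substituent on that phenyl, so it gives no direction for compound 3 in this assay. A step not beyond the scatter is therefore expected, with a wide range. Compound 3 is estimated at 1500 nM, between 500 nM and 4500 nM. The expected step is no change at the digits printed from compound 2 to compound 3 (within the scatter).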

Compound 3, half-maximal effective concentration: 24000 nM
Estimate against measurement, compound 3: 16-fold (1.20 log units) below; the whole stated range lies below it.
By their numbers in this assay, from the lowest: compound 2; then compound 1; then compound 3.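

In this assay, the aromatic carbon para to a large group on the benzyl ring proves sensitive to substitution: methoxycarbonyl in place of hydrogen gives a 16-fold higher number from compound 2 to compound 3 (1.20 log units; beyond the scatter). This more than cancels the gain seen with the unsubstituted phenyl, since 4-(methoxycarbonyl)phenyl in place of hydrogen on the chain carbon gives a 6.5-fold higher number from compound 1 to compound 3 (0.81 log units; beyond the scatter). No measured evidence accounts for this step.

The compounds shown leave open whether the higher number belongs to methoxycarbonyl specifically or to substitution at this carbon in general, as neither a carboxylic acid, an amide, an amine nor a halogen appears there. They also do not show whether methoxycarbonyl elsewhere on the phenyl ring, or a longer chain joining that ring to the core, would give a similar step.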